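This account rests on a few compounds, and the source may have more. Where it says the series, first, only, none or still open, it means among the compounds named here.

Three members of the series carry numbers in an assay on MDA-MB-231 cells for binding affinity to C-X-C chemokine receptor type 4 (Homo sapiens), read by immunofluorescence and microscopy, with stated times of 10 min and 30 min; on this read-out higher numbers stand for an effect only at larger amounts of compound and lower numbers for an effect already at smaller amounts. Within the data shown here, compound 1 `Cc1ccc(C(=O)NCc2ccc(CNS(=O)(=O)c3ccc(C)cc3)cc2)cc1` gives 1000 nM; compound 3 `Cc1ccc(S(=O)(=O)NCc2ccc(CNC(=O)c3ccccc3Cl)cc2)cc1` gives 10 nM, and the single change between them produces a 100-fold lower number from compound 1 to compound 3 (2.00 log units; beyond the scatter). Compound 2 `O=C(NCc1ccc(CNS(=O)(=O)c2ccccc2)cc1)c1ccncc1` gives 10 nM, level with compound 3 at the digits shown, the two together the lowest of the three numbers, while compound 1 stands far higher. Compound 4 `O=C(NCc1ccc(CNS(=O)(=O)c2ccccc2)cc1)c1ccccc1F` is the next member: 2-fluorophenyl in place of pyridin-4-yl on a carbonyl carbon. Among the measured compounds shown here, the only measured step that touches the group on a carbonyl carbon is a 100-fold lower number from compound 1 to compound 3 (2.00 log units; beyond the scatter), where a phenyl carrying chlorine replaced a phenyl carrying methyl; here a phenyl carrying fluorine replaces pyridin-4-yl, and compound 2 already sits at the low end. The expected step is no change at the digits printed from compound 2 to compound 4 (within the scatter), nothing beyond the scatter. Compound 4 is expected at 10 nM, range 3 nM to 40 nM.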

Compound 4, effective concentration (reported as EC, without a stated level of effect): 1000 nM
Estimate against measurement, compound 4: 100-fold (2.00 log units) below; measured number above the stated range.
By their numbers in this assay, from the lowest: compounds 2 and 3 (each within the scatter of the next); then compounds 1 and 4 (each within the scatter of the next).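

The group on the carbonyl carbon is not a tolerant place in this series: a 100-fold higher number from compound 2 to compound 4 (2.00 log units; beyond the scatter) shows that a change here can raise the number as sharply as the earlier step lowered it, so compound 2 does not mark a flat low end. The two large steps at this place run in opposite directions, but they start from different compounds. No measurement at hand bears on why the number moves here. Still open, on these data alone, is whether the rise goes with the loss of pyridin-4-yl or the entry of 2-fluorophenyl. Plain phenyl on the carbonyl carbon would separate the two.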